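The compounds below may be only part of what the source reports. "The series", "measured", "known", "first", "only" and "open" are said of these compounds alone.

Measured so far in a functional assay with Oryctolagus cuniculus as the target; on this read-out lower numbers stand for stronger inhibition and higher numbers for weaker inhibition:
compound 1 `CC/N=C(/N)Nc1nc(-c2ccc(OC)cc2)c(-c2ccc(OC)cc2)s1` gives > 100 nM, which is a limit of the assay.
compound 2 `COc1ccc(-c2nc(/N=C(\N)[N+]3(C)CCCCC3)sc2-c2ccc(OC)cc2)cc1` gives > 1000 nM, which is also a limit.

Compound 1 stands at the limit of > 100 nM in this assay, at which 1 of the 2 values shown sits, and no number is known for it. The second value shown is likewise a limit, at the limit of > 1000 nM in this assay, at which 1 of the 2 values shown sits. With two limits and no number, no order between the measured compounds can be read. Going by the values given here, the single measured step, a step that the two limits leave unreadable from compound 1 to compound 2, exchanges a group of 6 heavy atoms (3 carbon, 3 nitrogen; no ring) for a group of 10 heavy atoms (7 carbon, 3 nitrogen; one six-membered non-aromatic ring with 1 hetero atom) on an aromatic carbon; its size is not readable.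

Compound 3 `CNC(=O)NCc1nc(-c2ccc(OC)cc2)c(-c2ccc(OC)cc2)s1` differs from compound 1 by a group of 6 heavy atoms (3 carbon, 2 nitrogen, 1 oxygen; no ring) in place of a group of 6 heavy atoms (3 carbon, 3 nitrogen; no ring), on an aromatic carbon. The entering ((methylcarbamoyl)amino)methyl sits on an aromatic carbon of the shared core, next to the ring nitrogen and next to the ring sulfur. Among the compounds with values here, no measured step touches a change of this kind, and the one step measured is unreadable, so neither direction nor size can be drawn from the numbers. For compound 3 the step expected is a step that the limit leaves unreadable from compound 1 to compound 3. Compound 3 is estimated in this assay at 1000 nM, with a range from 150 nM to 10000 nM, most likely again reported as a limit.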

Compound 3, half-maximal inhibitory concentration: 22 nM
Beside the measured number, compound 3's estimate is 45-fold (1.66 log units) above it; the measured number lies below the stated range.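

Going by these compounds alone, compound 3 carries the first true number, so this aromatic carbon, next to the ring nitrogen and next to the ring sulfur, is now known to accept a group that gives a measurable read-out: ((methylcarbamoyl)amino)methyl. Exchanging the open-chain group of compound 1 for it gives an at least 4.5-fold lower number from compound 1 to compound 3 (0.65 log units; beyond the scatter) in this assay, although the two groups match in heavy atoms, double bonds outside aromatic rings, hydrogen-bond donors, hydrogen-bond acceptors and net charge, so these counts alone do not set the read-out at this position. Replacing the group with the six-membered non-aromatic ring by the same entering group gives an at least 45-fold lower number from compound 2 to compound 3 (1.65 log units; beyond the scatter), and this step too is a lower bound on the real change.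

The real size of the first step stays open, since compound 1 is known only as a limit: the limit of > 100 nM in this assay, at which 1 of the 3 values shown sits. It also stays open how the second step compares and whether a simple amine, a carboxylic acid or a longer chain at this aromatic carbon would keep the read-out, and compound 2 is likewise only a limit: the limit of > 1000 nM in this assay, at which 1 of the 3 values shown sits.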